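Aryl amine swap on a shared quinazoline-free core, cytotoxicity expected steady

The compounds below may be only part of what the source reports. "The series", "measured", "known", "first", "only" and "open" are said of these compounds alone.

Two compounds share one core and differ only in the group on the aromatic nitrogen. Compound 1 `FC(F)(F)c1ccc(CSc2nc(Nc3cccc(Cl)c3)c3ccccc3n2)cc1` in a functional assay on PC-3 cells (Homo sapiens) for cytotoxicity, read by MTT assay, with a stated time of 72 h (on this read-out lower numbers stand for stronger inhibition and higher numbers for weaker inhibition), gives 13400 nM. For the measured compounds named here, compound 2 `O=[N+]([O-])c1cccc(Nc2nc(SCc3ccc(C(F)(F)F)cc3)nc3ccccc23)c1` in this assay gives 13500 nM, and the step of a 1.0-fold higher number from compound 1 to compound 2 (0.00 log units; within the scatter) shows that the two numbers cannot be told apart, so compound 2 stands level with its only neighbour. The unmeasured compound 3 `Fc1ccc(Nc2nc(SCc3ccc(C(F)(F)F)cc3)nc3ccccc23)cc1` carries the change (4-fluorophenyl in place of 3-nitrophenyl on a nitrogen on an aromatic ring). Going by the values given here, the single measured step bears on compound 3 because a 1.0-fold higher number from compound 1 to compound 2 (0.00 log units; within the scatter) also exchanged the substituent on the same aryl amine without a shift beyond the scatter, and the same is expected here: a 1.0-fold lower number from compound 2 to compound 3 (0.02 log units; within the scatter) is estimated to be within the scatter. Compound 3 is therefore expected to give about 13000 nM in this assay, with a plausible range from 5000 nM to 35000 nM.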

Compound 3, half-maximal inhibitory concentration: 7070 nM
The estimate for compound 3 lay 1.8-fold (0.26 log units) above the measured number; low and high end bracket the measured number.
By their numbers in this assay, from the lowest: compounds 3, 1 and 2 (each within the scatter of the next).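

In this assay, 4-fluorophenyl in place of 3-nitrophenyl on the nitrogen gives a 1.9-fold lower number from compound 2 to compound 3 (0.28 log units; within the scatter) and 4-fluorophenyl in place of 3-chlorophenyl gives a 1.9-fold lower number from compound 1 to compound 3 (0.28 log units; within the scatter) and so neither exchange can be told from repeat-measurement noise. The earlier step covered only 3-chlorophenyl and 3-nitrophenyl, whereas these steps extend the same result to a third aryl group, 4-fluorophenyl, so that all three groups on this nitrogen remain indistinguishable on this read-out. No supporting evidence is available to explain these numbers.

On these data alone, it remains open whether an aryl group carrying an amine or a carboxylic acid, or a longer alkyl chain in place of the aryl ring, would give a step beyond the scatter. All three compounds also keep the rest of the shared core unchanged, so they say nothing about changes elsewhere.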